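Compound 1 to compound 3: a sulfonamide nitrogen substituent

This account rests on a few compounds, and the source may have more. Where it says the series, first, only, none or still open, it means among the compounds named here.

Within the data shown here, in a functional assay on UO-31 cells (Homo sapiens) for antiproliferative activity, read by sulforhodamine B assay, with a stated time of 72 h (on this read-out lower numbers stand for stronger inhibition and higher numbers for weaker inhibition), compound 1 `Cc1cc(C)nc(NS(=O)(=O)c2ccc(Nc3nncc4ccccc34)cc2)n1` gives 3.4 nM and holds the lower of the two numbers so far. Compound 2 `S=C(NNc1nncc2ccccc12)Nc1ccccc1` gives 56 nM in the same measurement, a gap beyond the usual scatter of repeated measurements.

Compound 3 `O=S(=O)(Nc1ncccn1)c1ccc(Nc2nncc3ccccc23)cc1` has not yet been measured. It keeps the core of compound 1 and differs in one place, with pyrimidin-2-yl in place of 4,6-dimethylpyrimidin-2-yl on a sulfonamide nitrogen as the whole change.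

Among the measured compounds shown here, no measured pair shows this change or anything close to it, so the data give no direct size for the step. The expectation therefore rests on compound 1 at 3.4 nM as the starting point, and it carries a wide margin. In this assay the expected step of a 2.1-fold higher number from compound 1 to compound 3 (0.31 log units; beyond the scatter) is a small one toward a higher number, possibly no larger than the scatter. For compound 3 the estimated value is 7 nM (expected range 2 nM to 35 nM).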

Compound 3, half-maximal inhibitory concentration: 23 nM
Compound 3: the middle estimate sits 3.3-fold (0.52 log units) below what was measured; the measured number falls inside the stated range.
By their numbers in this assay, from the lowest: compound 1; then compound 3; then compound 2.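

In this assay, among these compounds, pyrimidin-2-yl in place of 4,6-dimethylpyrimidin-2-yl on a sulfonamide nitrogen gives a 6.8-fold higher number from compound 1 to compound 3 (0.83 log units; beyond the scatter) as a modest step, the first direct reading of any change at this position, and it shows that the read-out responds to the substitution of this ring. The two groups match in ring type, hydrogen-bond donor and acceptor counts and net charge, so among the features counted here the step goes with the loss of the two methyl groups, a change from 8 heavy atoms to 6. Nothing available accounts for the size of this step.

This single pair cannot tell whether one methyl group would carry the same step as both, as a 4-methylpyrimidin-2-yl group on the same nitrogen would show. Also open, on these data alone, is whether the trend with added carbon continues with larger groups on the ring, such as 4,6-diethylpyrimidin-2-yl or 4,6-dimethoxypyrimidin-2-yl, or whether 4,6-dimethylpyrimidin-2-yl is already close to the limit of what this position accepts.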